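This account rests on a few compounds, and the source may have more. Where it says the series, first, only, none or still open, it means among the compounds named here.

Measured compounds:
compound 1 `O=C(OC1(C(=O)Nc2ccc([N+](=O)[O-])cc2)CCCCC1)c1ccc(C(F)(F)F)cc1` 26 nM
compound 2 `O=C(/C=C/c1ccccc1)OC1(C(=O)Nc2ccc([N+](=O)[O-])cc2)CCCCC1` 50.5 nM
compound 3 `O=C(OC1(C(=O)Nc2ccc([N+](=O)[O-])cc2)CCCCC1)c1ccccc1` 766 nM

In a functional assay on NFS-60 cells (Mus musculus) for inhibition, read by MTT assay, with a stated time of 72 h (on this read-out lower numbers stand for stronger inhibition and higher numbers for weaker inhibition), compound 3 stands at the top of the three numbers, which on this read-out is the weakest inhibition shown. Its nearest neighbour is compound 2, and the separation is a 15-fold higher number from compound 2 to compound 3 (1.18 log units; beyond the scatter); the furthest is compound 1, at a 29-fold higher number from compound 1 to compound 3 (1.47 log units; beyond the scatter). Both steps that lead to compound 3 are beyond the scatter, and both remove or shorten part of the ester side of the shared core. The remaining step, a 1.9-fold higher number from compound 1 to compound 2 (0.29 log units; within the scatter), lies within the scatter.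

Compound 4 `O=COC1(C(=O)Nc2ccc([N+](=O)[O-])cc2)CCCCC1` continues in the same direction: hydrogen in place of phenyl on a carbonyl carbon. Among the compounds with values here, no measured pair covers exactly this change, so the expectation rests on the two large steps into compound 3. Each time the ester was trimmed the number rose sharply, and taking away the whole phenyl is the largest trimming of the set. A further weakening is therefore expected, though its size cannot be read off a matching pair. Compound 4 is estimated at 3000 nM, within 800 nM to 15000 nM, which means an expected step of a 3.9-fold higher number from compound 3 to compound 4 (0.59 log units; beyond the scatter) in this assay.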

Compound 4, half-maximal inhibitory concentration: 33.8 nM
For compound 4 the middle estimate is 89-fold (1.95 log units) above the measured one; the whole stated range lies above it.
By their numbers in this assay, from the lowest: compounds 1, 4 and 2 (each within the scatter of the next); then compound 3.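

In this assay, a 23-fold lower number from compound 3 to compound 4 (1.36 log units; beyond the scatter) shows that a bare hydrogen on this carbonyl carbon, with no ring or chain at all, can give a far lower number than phenyl, so the rise seen at compound 3 does not come simply from having less group at this place. With a 1.5-fold lower number from compound 2 to compound 4 (0.17 log units; within the scatter) and a 1.3-fold higher number from compound 1 to compound 4 (0.11 log units; within the scatter), both within the scatter, hydrogen, 2-phenylethenyl and 4-(trifluoromethyl)phenyl cannot be told apart here, which leaves compound 3, with its unsubstituted phenyl, alone as the weakest of the four and the only one separated from the others beyond the scatter. The size of the group therefore sets no trend across these compounds, and nothing given here accounts for why the plain benzoyl ester stands apart.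

The compounds shown leave open whether a methyl or a longer alkyl chain on this carbonyl carbon would stay with compound 4 or move towards compound 3. They also leave open whether a methoxy group, a chlorine or an amine on the phenyl ring in place of trifluoromethyl would bring the number down as trifluoromethyl does.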